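Compound 1 and a Swap of Its Naphthalene Group

The compounds below may be only part of what the source reports. "The series", "measured", "known", "first", "only" and "open" are said of these compounds alone.

Measured in a functional assay on HL-60 cells (Homo sapiens) for inhibition, read by CCK-8 assay, with a stated time of 48 h, tested at 20 uM; a higher number here means more inhibition of growth at the concentration tested, a lower number less inhibition of growth:
Compound 1 `Cc1ccc(S(=O)(=O)Oc2ccccc2/C=C(\C#N)C(=O)Nc2nnc(Cc3cccc4ccccc34)s2)cc1`: 19%
Compound 2 `N#C/C(=C\c1ccccc1OS(=O)(=O)c1ccc(Cl)cc1)C(=O)Nc1nnc(Cc2cccc3ccccc23)s1`: 15%

The values of compound 1 and compound 2 lie within the usual scatter of each other, so these two numbers do not rank them. Compound 3 `Cc1ccc(S(=O)(=O)Oc2ccccc2/C=C(\C#N)C(=O)Nc2nnc(Cc3ccc(Cl)cc3)s2)cc1` keeps the rest of compound 1 and differs at one place: 4-chlorophenyl in place of naphthalen-1-yl on a saturated chain carbon bound to an aromatic carbon. Among the compounds with values here, only one measured step bears on this, and only indirectly: a number 4 percentage points lower from compound 1 to compound 2 (within the scatter). Within the data shown here, that step concerns a different group, chloro in place of methyl on an aromatic carbon, and no measured step yet replaces naphthalen-1-yl. On this thin evidence, no step beyond the scatter is expected in this assay, and neither direction is favoured. The expected step runs a number 2 percentage points lower from compound 1 to compound 3 (within the scatter). Compound 3 is estimated at 17%, with an expected range of 5% to 35%.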

Compound 3, percent growth inhibition at one concentration: 15%
Beside the measured number, compound 3's estimate is 2 percentage points above it; measured number inside the range.
By their numbers in this assay, from the lowest: compounds 2, 3 and 1 (each within the scatter of the next).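

In this assay, within the data shown here, the first change at this position, from naphthalen-1-yl to 4-chlorophenyl on a saturated chain carbon bound to an aromatic carbon, gives a number 4 percentage points lower from compound 1 to compound 3 (within the scatter) and so does not separate the two compounds. An aromatic group of two rings and 10 heavy atoms thus gives way to one ring and 7 heavy atoms, including a chlorine, with no step beyond the scatter, although this single swap changes both ring count and chlorine content and cannot divide the result between them. Nothing at hand explains this reading.

The compounds shown leave open whether an aromatic group is needed here at all. On these data alone, it also remains open whether an amine, a carboxylic acid or a longer chain at this place would give a step beyond the scatter.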